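The compounds below may be only part of what the source reports. "The series", "measured", "known", "first", "only" and "open" are said of these compounds alone.

Compound 1 `O=C(O)c1ccc(C(=O)/C=C/c2ccc3c(c2)B(O)OC3)cc1` has been tested in an ADME assay on L929 cells (Mus musculus) for cytotoxicity, read by resazurin assay, with a stated time of 72 h (a higher number here means a weaker inhibitor, a lower number a stronger inhibitor), where compound 1 gives > 10 ug/mL, which is a limit of the assay rather than a number. Compound 1 therefore stands at the limit of > 10 ug/mL in this assay, at which 2 of the 3 values shown sit. Compound 2 `COc1ccccc1C(=O)/C=C/c1ccc2c(c1)B(O)OC2` gives 6.35 ug/mL in this assay. Compound 3 `COc1cccc(C(=O)CCc2ccc3c(c2)B(O)OC3)c1` gives > 10 ug/mL in this assay, again a limit. Compound 4 `Nc1ccc(C(=O)/C=C/c2ccc3c(c2)B(O)OC3)cc1` has not yet been measured in this assay. It differs from compound 1 in one place: amino in place of carboxy on an aromatic carbon. No step between two measured compounds is recorded, so the size of this change cannot be read from the numbers shown. The step of an at least 1.2-fold lower number from compound 1 to compound 4 (0.09 log units; that floor lies within the scatter) is expected to be small, within the usual scatter, leaning if anywhere toward a stronger inhibitor. Compound 4 is expected to give 8 ug/mL, with a range from 3 ug/mL to 20 ug/mL.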

Compound 4, half-maximal inhibitory concentration: > 10 ug/mL
Compound 4: no number, only a limit (the forecaster's own chance of this, stated with the estimate: 50%); middle value at least 1.2-fold (0.09 log units) away from the limit.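

Compound 1 and compound 4 both give only a limit, so no step can be read between them: the limit of > 10 ug/mL in this assay, at which 3 of the 4 values shown sit. The compounds shown leave open the size and direction of the change when amino takes the place of carboxy.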